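Working notes: a hydroxy group on compound 2

This account rests on a few compounds, and the source may have more. Where it says the series, first, only, none or still open, it means among the compounds named here.

In a functional assay on PC-3 cells (Homo sapiens) for inhibition, read by sulforhodamine B assay (a higher number here means a weaker inhibitor of growth, a lower number a stronger inhibitor of growth), compound 1 (`FC(F)(F)c1ccc(-c2ccc(-c3ccc(-c4nc5ccccc5[nH]4)cc3)cc2)cc1`) gives 45200 nM, compound 2 (`FC(F)(F)Oc1ccc(-c2ccc(-c3ccc(-c4nc5ccccc5[nH]4)cc3)cc2)cc1`) gives 100000 nM and compound 3 (`CN(C)c1ccc(-c2ccc(-c3ccc(-c4nc5ccccc5[nH]4)cc3)cc2)cc1`) gives 100000 nM. Compound 2 is level with compound 3, and together they hold the highest of the three numbers.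

Compound 4 (`Oc1cccc2[nH]c(-c3ccc(-c4ccc(-c5ccc(OC(F)(F)F)cc5)cc4)cc3)nc12`) has hydroxy in place of hydrogen on an aromatic carbon, turning 1H-benzimidazol-2-yl into 4-hydroxy-1H-benzimidazol-2-yl: hydroxy in place of hydrogen on an aromatic carbon.

The measured steps all exchange a different substituent: a 2.2-fold higher number from compound 1 to compound 2 (0.34 log units; beyond the scatter), a 2.2-fold higher number from compound 1 to compound 3 (0.34 log units; beyond the scatter) and no change at the digits printed from compound 2 to compound 3 (within the scatter). The first two are modest and the third lies within the scatter. None alters the 1H-benzimidazol-2-yl group, so the data contain no direct test of this change and offer only a general guide to step size. A modest move towards a lower number is expected, on weak grounds, since compound 2 already shares the highest number. The estimated change is a 2.5-fold lower number from compound 2 to compound 4 (0.40 log units; beyond the scatter). For compound 4, the estimated value is 40000 nM, with an expected range of 8000 nM to 100000 nM.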

Compound 4, concentration for 50% growth inhibition: 7410 nM
Compound 4: middle estimate off by 5.4-fold (0.73 log units), on the high side, and the stated range ends above it.
By their numbers in this assay, from the lowest: compound 4; then compound 1; then compounds 2 and 3 (each within the scatter of the next).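

In this assay, hydroxy in place of hydrogen gives a 13-fold lower number from compound 2 to compound 4 (1.13 log units; beyond the scatter) and is the first change shown on the 1H-benzimidazol-2-yl group, as the earlier steps exchanged only trifluoromethyl, trifluoromethoxy and dimethylamino at the other end of the molecule. This single added group moves the number further than any of those exchanges, so among the sites shown, this aromatic carbon is the more responsive in this series. No measured information on the compounds accounts for the size of this step.

The compounds shown leave open whether the shift is specific to hydroxy or would also appear with methoxy, fluorine or an amine on the same carbon. They also leave open whether the same hydroxy group would lower the number on the trifluoromethyl or dimethylamino analogues.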